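Sulfone Series Notes: Second Trifluoromethyl on the Aryl Sulfone

The source may report more compounds than this note shows. Statements on the series, on what has been measured and on what is new or still open speak of the compounds shown alone.

Measured so far:
- compound 1 `CC(O)(COc1ccc(C#N)cc1)C(=O)Nc1ccc(S(F)(F)(F)(F)F)cc1`: 100000 nM
- compound 2 `CC(O)(COc1ccc(C#N)cc1C(F)(F)F)C(=O)Nc1ccc(S(F)(F)(F)(F)F)cc1`: 100000 nM
- compound 3 `CC(O)(CS(=O)(=O)c1cccc(C(F)(F)F)c1)C(=O)Nc1cccc(S(F)(F)(F)(F)F)c1`: 21800 nM

In a functional assay on LNCaP cells (Homo sapiens) for antiproliferative activity, read by propidium iodide staining, with a stated time of 96 h (on this read-out lower numbers stand for stronger inhibition and higher numbers for weaker inhibition), compound 1 gives 100000 nM and compound 2 gives 100000 nM. The change between them is trifluoromethyl in place of hydrogen on an aromatic carbon and its step is no change at the digits printed from compound 1 to compound 2 (within the scatter). Compound 3 gives 21800 nM, the lowest value of the three; how its core differs from that of compound 1 is not broken down here.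

Compound 4 `CC(O)(CS(=O)(=O)c1cc(C(F)(F)F)cc(C(F)(F)F)c1)C(=O)Nc1cccc(S(F)(F)(F)(F)F)c1` is not yet measured. It differs from compound 3 by trifluoromethyl in place of hydrogen on an aromatic carbon. This is the same kind of change as from compound 1 to compound 2, though the place differs: in compound 2 the entering group sits ortho to a large group and meta to a cyano group, in compound 4 meta to a large group and meta to a trifluoromethyl group. Within the data shown here, since the one earlier instance of this change gave no shift beyond the scatter, the expected step of a 1.1-fold lower number from compound 3 to compound 4 (0.04 log units; within the scatter) is small, set beside no change at the digits printed from compound 1 to compound 2 (within the scatter). Compound 4 is estimated at 20000 nM, with a range of 7000 nM to 60000 nM.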

Compound 4, half-maximal inhibitory concentration: 9700 nM
Compound 4: the middle estimate sits 2.1-fold (0.31 log units) above what was measured; the range from low to high includes it.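

In this assay, trifluoromethyl in place of hydrogen on an aromatic carbon gives a 2.2-fold lower number from compound 3 to compound 4 (0.35 log units; beyond the scatter) on the core of compound 3, a modest gain and the lowest number in this short set. This does not show that the group makes a fixed contribution on every core: there are only two instances, they sit at different places on different cores, and neither step says why the numbers moved. Carried from the core of compound 1 to the core of compound 3, the change gives steps that cannot be told apart, so the data neither show a dependence on the core nor prove that there is none: the same change on two cores in this assay, no change at the digits printed (within the scatter) from compound 1 to compound 2 and a 2.2-fold lower number (0.35 log units; beyond the scatter) from compound 3 to compound 4, 2.2-fold (0.35 log units) apart, within the scatter of two such steps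

Still open, as far as these compounds go, is whether a group other than trifluoromethyl, such as a chlorine, a methoxy group or an amine, would move the number in the same direction when placed on the same aromatic carbon of compound 4. Also open, from the compounds shown here alone, is how far this step holds when the hydroxyl group of the shared chain gives way to an amine or a carboxylic acid.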